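Chlorophenyl for nitrophenyl: cytotoxicity outlook for compound 4

The source may hold more compounds than are shown below. What is called first, only, known or untested is meant among the compounds shown, and "the series" means these compounds.

The series shares one core, seen in compound 1 `O=C(/C=C\c1ccccc1[N+](=O)[O-])N1N=C(c2ccncc2)OC1c1c[nH]c2ccccc12`, compound 2 `O=C(/C=C\c1cccc([N+](=O)[O-])c1)N1N=C(c2ccncc2)OC1c1c[nH]c2ccccc12` and compound 3 `O=C(/C=C\c1ccccc1F)N1N=C(c2ccncc2)OC1c1c[nH]c2ccccc12`, with only the aryl group on the double-bonded chain carbon varied. In an ADME assay on A549 cells (Homo sapiens) for cytotoxicity, read by MTT assay, with a stated time of 48 h (a higher number here means a weaker inhibitor of growth, a lower number a stronger inhibitor of growth), compound 1 gives > 30 ug/mL, a limit of the assay rather than a number. In this assay compound 2 gives > 30 ug/mL, again a limit. In this assay compound 3 gives > 30 ug/mL, also a limit. Compound 2 thus stands at the limit together with the other two members, and the limit of > 30 ug/mL in this assay, at which 3 of the 3 values shown sit, is all that the three values show. The steps a step that the two limits leave unreadable from compound 1 to compound 2, a step that the two limits leave unreadable from compound 1 to compound 3 and a step that the two limits leave unreadable from compound 2 to compound 3 cannot be sized.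

Compound 4 `O=C(/C=C\c1ccccc1Cl)N1N=C(c2ccncc2)OC1c1c[nH]c2ccccc12` is not yet measured. Its change from compound 2 is 2-chlorophenyl in place of 3-nitrophenyl on a double-bonded chain carbon bound to a double-bonded chain carbon. The measured steps bearing on it are the three aryl exchanges among compounds 1, 2 and 3, each unreadable, and none of them shows any member leaving the limit. No step beyond the scatter is therefore expected in this assay, and another limit is the most likely outcome. For compound 4 the expected value is 40 ug/mL, with a range of 20 ug/mL to 90 ug/mL. The estimated step is a step that the limit leaves unreadable from compound 2 to compound 4.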

Compound 4, concentration for 50% growth inhibition: > 30 ug/mL
Compound 4 ended at the assay's limit (the forecaster's own chance of this, stated with the estimate: 85%); the middle value is on the limit's open side.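

Compound 4 gives > 30 ug/mL in this assay, a limit of the assay, so its steps to compound 1, compound 2 and compound 3 cannot be read: the limit of > 30 ug/mL in this assay, at which 4 of the 4 values shown sit.

The compounds shown leave open how the four members differ in growth inhibition, and whether any aryl exchange on the shared core gives a readable value.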